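From ethoxy to methylamino on the carbonyl of compound 3

The source may report more compounds than this note shows. Statements on the series, on what has been measured and on what is new or still open speak of the compounds shown alone.

In an ADME assay on L929 cells (Mus musculus) for cytotoxicity, read by resazurin assay, with a stated time of 48 h (on this read-out higher numbers stand for lower toxicity in this test and lower numbers for higher toxicity in this test), compound 1 `C#CCn1c2ccc([N+](=O)[O-])cc2c(=O)n1Cc1ccccc1` gives 195000 nM and compound 2 `O=c1c2cc([N+](=O)[O-])ccc2n(CCCBr)n1Cc1ccccc1` gives 25200 nM. Compound 3 `CCOC(=O)CCCn1c2ccc([N+](=O)[O-])cc2c(=O)n1Cc1ccccc1` gives 78100 nM, the middle of the three numbers. Compound 4 `CNC(=O)CCCn1c2ccc([N+](=O)[O-])cc2c(=O)n1Cc1ccccc1` carries methylamino in place of ethoxy on a carbonyl carbon. Within the data shown here, no measured step makes this exact change, so the nearest guides are the changes at the end of the chain, which stayed modest: a 2.5-fold lower number from compound 1 to compound 3 (0.40 log units; beyond the scatter) and a 3.1-fold higher number from compound 2 to compound 3 (0.49 log units; beyond the scatter). A modest move is therefore expected, and its direction is only a tentative call, as a 1.5-fold higher number from compound 3 to compound 4 (0.17 log units; within the scatter) in this assay. For compound 4 the estimated value is 115000 nM, with an expected range of 45000 nM to 290000 nM.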

Compound 4, concentration lethal to 50% of the cells: > 256000 nM
Compound 4: a limit, no number (the forecaster's own chance of this, stated with the estimate: 10%); middle value at least 2.2-fold (0.34 log units) from the limit.
By their numbers in this assay, from the lowest: compound 2; then compound 3; then compound 1. At a limit, above all of these: compound 4.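

The value of compound 4 in this assay is a limit, not a number: the limit of > 256000 nM in this assay, at which 1 of the 4 values shown sits.

Even so, methylamino in place of ethoxy on the carbonyl carbon brings an at least 3.2-fold higher number from compound 3 to compound 4 (0.51 log units; beyond the scatter), showing that this carbonyl substituent alone can shift the read-out, and the comparison with the bromo compound reaches an at least 10-fold higher number from compound 2 to compound 4 (1.00 log units; beyond the scatter). Against the ethynyl compound the step is an at least 1.3-fold higher number from compound 1 to compound 4 (0.11 log units; that floor lies within the scatter), so the size of that difference stays unsettled.

The compounds shown leave open how a dimethylamino group or a carboxylic acid on this carbonyl carbon would read, and whether the amide hydrogen matters.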